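The compounds below may be only part of what the source reports. "The series", "measured", "known", "first", "only" and "open" are said of these compounds alone.

The study concerns a set of compounds sharing one core and tested for their effect on paw edema in the rat. Compound 1 `C=CCn1c(SCC(=O)Nc2ccc(/C(C)=N/O)cc2)nnc1-c1ccccc1` and compound 2 `COc1ccc(-c2nnc(SCC(=O)Nc3ccc(/C(C)=N/O)cc3)n2-c2ccccc2)cc1OC` have been measured. In a functional assay on the whole organism (strain albino) for inhibition, with Rattus norvegicus as the target, read by paw edema, with stated times of 30 min and 4 h, at a dose of 0.28 mmol/kg by the oral route (on this read-out lower numbers stand for less inhibition and higher numbers for more inhibition at the one dose given (going by the name of the read-out)), compound 1 gives 73%. In this assay compound 2 gives 79%, the higher of the two numbers on record, though the gap to compound 1 lies within the usual scatter of this kind of measurement, so no order between the two can be read from it.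

Compound 3 `C=CCn1c(SCC(=O)Nc2ccc(/C(C)=N/O)cc2)nnc1-c1ccc(OC)c(OC)c1` has not yet been measured. It differs from compound 2 in one place: allyl in place of phenyl on an aromatic nitrogen. Among the compounds with values here, compound 1 already carries an allyl group at that same position and, in this assay, sits close to compound 2; no single-change step between measured compounds is available to size this exchange directly.

On that basis the step from compound 2 to compound 3 in this assay is expected to be a number 3 percentage points lower from compound 2 to compound 3 (within the scatter), no movement beyond the scatter in either direction. Compound 3 is therefore estimated at 76% in this assay, within a range from 62% to 88%.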

Compound 3, a percentage reported as inhibition, in the whole organism at one dose (the size of the read-out at that dose, not a potency): 79%
Estimate against measurement, compound 3: 3 percentage points below; measured number inside the range.
By their numbers in this assay, from the lowest: compounds 1, 2 and 3 (each within the scatter of the next).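

In this assay, the exchange of phenyl for allyl on the aromatic nitrogen can now be sized directly, and it gives no change at the digits printed from compound 2 to compound 3 (within the scatter): at this position, a group with no ring and 3 heavy atoms and a group with one six-membered aromatic ring and 6 heavy atoms cannot be told apart on this read-out at the one dose given. Within the data shown here, compound 3 also provides the first single-change comparison at the aromatic carbon: with allyl held on the nitrogen, 3,4-dimethoxyphenyl in place of phenyl gives a number 6 percentage points higher from compound 1 to compound 3 (within the scatter), so neither exchange moves the read-out beyond the scatter. Nothing available bears on what lies behind these two steps.

On these data alone, both groups compared on the nitrogen consist of carbon only, so it remains open whether a longer chain ending in an amine or a carboxylic acid at that position would leave the inhibition of paw edema where it stands. All three compounds are also compared at a single dose, which leaves open whether either exchange would stay within the scatter at another dose.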